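From Phenylethenyl to Trimethoxyphenyl on the Saturated Ring Carbon

The source may report more compounds than this note shows. Statements on the series, on what has been measured and on what is new or still open speak of the compounds shown alone.

Three measured compounds share one core and differ only in the group on a saturated ring carbon. Compound 1 `Cc1cc(O)c(C2=NN(c3ccc(S(N)(=O)=O)cc3)C(c3ccccc3Cl)C2)cc1Cl` carries a 2-chlorophenyl there, and in a functional assay on SK-MEL-2 cells (Homo sapiens) for antiproliferative activity, with a stated time of 48 h (on this read-out higher numbers stand for lower toxicity in this test and lower numbers for higher toxicity in this test), compound 1 gives 81100 nM. Compound 2 `Cc1cc(O)c(C2=NN(c3ccc(S(N)(=O)=O)cc3)C(/C=C/c3ccccc3)C2)cc1Cl` carries a 2-phenylethenyl instead. In this assay compound 2 gives > 100000 nM, which is a limit of the assay rather than a number. Compound 3 `COc1ccc(C2CC(c3cc(Cl)c(C)cc3O)=NN2c2ccc(S(N)(=O)=O)cc2)cc1OC` carries a 3,4-dimethoxyphenyl. In this assay compound 3 gives > 100000 nM, again a limit and not a number. Compound 2 therefore stands at the limit of > 100000 nM in this assay, at which 2 of the 3 values shown sit. The steps away from compound 1 are an at least 1.2-fold higher number from compound 1 to compound 2 (0.09 log units; that floor lies within the scatter) and an at least 1.2-fold higher number from compound 1 to compound 3 (0.09 log units; that floor lies within the scatter); between the two limits the step is a step that the two limits leave unreadable from compound 2 to compound 3.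

Compound 4 `COc1ccc(C2CC(c3cc(Cl)c(C)cc3O)=NN2c2ccc(S(N)(=O)=O)cc2)c(OC)c1OC` has not been measured. It differs from compound 2 in one place: 2,3,4-trimethoxyphenyl in place of 2-phenylethenyl on a saturated ring carbon. Among the compounds with values here, the measured step that comes closest to this change is the one ending in compound 3, a methoxy-bearing ring whose value > 100000 nM is a limit, so no step beyond the scatter can be read from it. Compound 4 is thus expected to sit at or near that same limit, estimated at 100000 nM, within 50000 nM to 200000 nM. The expected step is a number no higher from compound 2 to compound 4 (the limit leaves the size open), nothing beyond the scatter.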

Compound 4, concentration lethal to 50% of the cells: 71300 nM
Compound 4: the middle estimate sits 1.4-fold (0.15 log units) above what was measured, within the range that was stated.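

What is new is a measured number for a methoxy-bearing ring on this saturated ring carbon, where compound 2 and compound 3 each gave only a limit of the assay: the limit of > 100000 nM in this assay, at which 2 of the 4 values shown sit. In this assay the steps are an at least 1.4-fold lower number from compound 2 to compound 4 (0.14 log units; that floor lies within the scatter) and an at least 1.4-fold lower number from compound 3 to compound 4 (0.14 log units; that floor lies within the scatter), so neither replacing 2-phenylethenyl with 2,3,4-trimethoxyphenyl nor putting methoxy in place of hydrogen on an aromatic carbon gives a floor that shows a change beyond the scatter. Compared with the 2-chlorophenyl group, the result is a 1.1-fold lower number from compound 1 to compound 4 (0.06 log units; within the scatter), so these two groups cannot be told apart here, and no step at this position has yet been shown to lie beyond the scatter.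

On these data alone, whether a group of a different kind on this carbon, such as a phenyl ring bearing an amine or a carboxylic acid, or a plain longer alkyl chain, would give a step beyond the scatter stays open. As far as these compounds go, how far compound 2 and compound 3 really lie from compound 4 also stays open, since the limits give no exact position.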